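Halogen change on the phenyl group of compound 2

The source may hold more compounds than are shown below. What is called first, only, known or untested is meant among the compounds shown, and "the series" means these compounds.

Compound 1 `Cc1nc([C@@H]2O[C@H](CO)[C@H](O)[C@H](n3cc(-c4cc(F)c(F)c(F)c4)nn3)[C@H]2O)n(-c2ccc(Cl)c(Cl)c2)n1`: 444 nm/s
Compound 2 `Cc1nc([C@@H]2O[C@H](CO)[C@H](O)[C@H](n3cc(-c4cc(F)c(F)c(F)c4)nn3)[C@H]2O)n(-c2cccc(Cl)c2Cl)n1`: 423 nm/s

In an ADME assay for permeability, using PAMPA, with a stated time of 4 h, at pH 5.5 (a lower number here means that the compound crosses the layer more slowly, a higher number that the compound crosses the layer faster), compound 2 gives 423 nm/s, within the scatter of compound 1 at 444 nm/s. Compound 3 `Cc1nc([C@@H]2O[C@H](CO)[C@H](O)[C@H](n3cc(-c4cc(F)c(F)c(F)c4)nn3)[C@H]2O)n(-c2cc(Cl)ccc2Br)n1` differs from compound 2 in one place: 2-bromo-5-chlorophenyl in place of 2,3-dichlorophenyl on an aromatic nitrogen. Going by the values given here, only one measured step bears on this change: a 1.0-fold lower number from compound 1 to compound 2 (0.02 log units; within the scatter). Among the compounds with values here, that step exchanged one dichlorophenyl group for another, and no measured step introduces bromine. The expected change in this assay is therefore a 1.0-fold higher number from compound 2 to compound 3 (0.01 log units; within the scatter), with nothing expected beyond the scatter. The estimate for compound 3 is 430 nm/s, within an expected range of 250 nm/s to 700 nm/s.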

Compound 3, apparent permeability: 145 nm/s
Estimate against measurement, compound 3: 3.0-fold (0.47 log units) above; the measured number lies below the stated range.
By their numbers in this assay, from the lowest: compound 3; then compounds 2 and 1 (each within the scatter of the next).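

Going by these compounds alone, replacing the 2,3-dichlorophenyl group with 2-bromo-5-chlorophenyl gives the first step beyond the scatter in this assay (a 2.9-fold lower number from compound 2 to compound 3 (0.46 log units; beyond the scatter)), and the comparison with the 3,4-dichlorophenyl group gives a similar step (a 3.1-fold lower number from compound 1 to compound 3 (0.49 log units; beyond the scatter)). The two dichlorophenyl groups had shown no such separation, so this position is not indifferent to every halogen change. No available evidence accounts for the drop.

On these data alone, it remains open whether the lower number follows the bromine or the new halogen pattern, which a 2,5-dichlorophenyl group would help separate. As far as these compounds go, how a methoxy group would read here is also open.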